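A few compounds are considered here, and "the series" means these few. Any claim that something is new, unique, unknown or untested is made for them only; others in the source may bear on it.

Measured compounds in a functional assay on the whole organism (strain Wistar) for inhibition, with Rattus norvegicus as the target, read by paw edema, with a stated time of 4 h, at a dose of 10 mg/kg by the intraperitoneal route; on this read-out lower numbers stand for less inhibition and higher numbers for more inhibition at the one dose given (going by the name of the read-out):
compound 1, `O=C(N/N=C/c1cccc(F)c1)c1cccnc1Nc1cccc(C(F)(F)F)c1`, 29.8%
compound 2, `O=C(N/N=C/c1ccc(F)cc1)c1cccnc1Nc1cccc(C(F)(F)F)c1`, 36.5%
compound 3, `COc1ccc(/C=N/NC(=O)c2cccnc2Nc2cccc(C(F)(F)F)c2)cc1OC`, 52.9%

Compound 3 stands highest of the three numbers, with compound 2 nearest and compound 1 furthest; both gaps to it are beyond the scatter. The two fluorophenyl compounds sit within the scatter of each other, as the step of a number 6.7 percentage points higher from compound 1 to compound 2 (within the scatter) shows.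

Compound 4, `CN(C)c1ccc(/C=N/NC(=O)c2cccnc2Nc2cccc(C(F)(F)F)c2)cc1`, is not yet measured. Its difference from compound 3 is 4-(dimethylamino)phenyl in place of 3,4-dimethoxyphenyl on a carbon with a double bond to nitrogen.

Among the measured compounds shown here, no measured step exchanges a 3,4-dimethoxyphenyl for a 4-(dimethylamino)phenyl, so no step bears on this change directly. The steps that touch the same position are a number 23.1 percentage points higher from compound 1 to compound 3 (beyond the scatter) and a number 16.4 percentage points higher from compound 2 to compound 3 (beyond the scatter), both modest and both rising toward compound 3. They show only that this position moves the read-out by modest amounts and that compound 3 holds the highest number seen. Without a closer comparison, compound 4 is expected to land near compound 3 or somewhat under it, the step of a number 7.9 percentage points lower from compound 3 to compound 4 (within the scatter) being expected to stay within or close to the scatter. For compound 4 the estimate in this assay is 45%, between 30% and 60%.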

Compound 4, a percentage reported as inhibition, in the whole organism at one dose (the size of the read-out at that dose, not a potency): 28.2%
Compound 4: middle estimate off by 16.8 percentage points, on the high side; measured number outside the range, below it.
By their numbers in this assay, from the lowest: compounds 4, 1 and 2 (each within the scatter of the next); then compound 3.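

In this assay, the exchange of 3,4-dimethoxyphenyl for 4-(dimethylamino)phenyl on the carbon with a double bond to nitrogen gives a number 24.7 percentage points lower from compound 3 to compound 4 (beyond the scatter), so the high number of compound 3 does not carry over to this other substituted phenyl group. The steps of a number 8.3 percentage points lower from compound 2 to compound 4 (within the scatter) and a number 1.6 percentage points lower from compound 1 to compound 4 (within the scatter) leave compound 4 level with the two fluorophenyl compounds, and among the four groups shown at this position, only the 3,4-dimethoxyphenyl of compound 3 stands apart, with all its steps to the others beyond the scatter. Nothing available here says why these groups part in this way.

The compounds shown leave open whether a single methoxy group, as in a 4-methoxyphenyl or a 3-methoxyphenyl, would hold the number that compound 3 gives, 52.9%, or whether both methoxy groups are needed for it. They also leave open how a hydroxyl group or a primary amine would read on the same phenyl ring, and whether the standing of the 3,4-dimethoxyphenyl group would survive a change elsewhere in the shared core.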